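Compound 3 to compound 4: bromo replaced by ethoxy

The source may hold more compounds than are shown below. What is called first, only, known or untested is meant among the compounds shown, and "the series" means these compounds.

Among the measured compounds shown here, in a functional assay on HepG2 cells (Homo sapiens) for antiproliferative activity, read by MTT assay, with a stated time of 48 h (a higher number here means a weaker inhibitor, a lower number a stronger inhibitor), three members have numbers so far. Compound 1 `CCCC(C)Oc1ccc(C(=O)/C=C/c2c(/C=C/c3ccc(OC)cc3)cc(OC)cc2OC)cc1` gives 11.1 ug/mL. Compound 2 `COc1ccc(/C=C/c2cc(OC)cc(OC)c2/C=C/C(=O)c2cccc(Cl)c2)cc1` gives 9.5 ug/mL. Compound 3 `COc1ccc(/C=C/c2cc(OC)cc(OC)c2/C=C/C(=O)c2ccc(Br)cc2)cc1` gives 12.9 ug/mL. Compound 3 therefore stands level with the other two, since every gap among the three lies within the scatter and the numbers set no order.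

Compound 4 `CCOc1ccc(C(=O)/C=C/c2c(/C=C/c3ccc(OC)cc3)cc(OC)cc2OC)cc1` keeps the core of compound 3 and differs in one place: ethoxy in place of bromo on an aromatic carbon. This is ethoxy in place of bromo on an aromatic carbon, para to a large group.

The closest measured change is bromo in place of 1-methylbutoxy at that same place, which gave a 1.2-fold higher number from compound 1 to compound 3 (0.07 log units; within the scatter). The change from 3-chlorophenyl to 4-bromophenyl on the carbonyl carbon gave a 1.4-fold higher number from compound 2 to compound 3 (0.13 log units; within the scatter), and the remaining pair shows a 1.2-fold lower number from compound 1 to compound 2 (0.07 log units; within the scatter). All three steps stay within the scatter. For the measured compounds named here, no ethoxy compound has been measured yet, so this rests on a small set, but nothing in it points to a large shift in this assay. The expected step is a 1.2-fold lower number from compound 3 to compound 4 (0.07 log units; within the scatter), with no direction expected beyond the scatter. The estimated value for compound 4 is 11 ug/mL, with an expected range of 6 ug/mL to 20 ug/mL.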

Compound 4, half-maximal inhibitory concentration: 8 ug/mL
For compound 4 the middle estimate is 1.4-fold (0.14 log units) above the measured one; measured number inside the range.
By their numbers in this assay, from the lowest: compounds 4, 2, 1 and 3 (each within the scatter of the next).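

In this assay, among the compounds shown here, the aromatic carbon para to a large group now carries a short alkoxy chain for the first time: ethoxy in place of bromo gives a 1.6-fold lower number from compound 3 to compound 4 (0.21 log units; within the scatter) and, at the same place, ethoxy in place of 1-methylbutoxy gives a 1.4-fold lower number from compound 1 to compound 4 (0.14 log units; within the scatter) as the second reading, so bromo, ethoxy and 1-methylbutoxy stand level here and neither the halogen nor the length of the chain separates the compounds. Set against the 3-chlorophenyl on the carbonyl carbon, 4-ethoxyphenyl gives a 1.2-fold lower number from compound 2 to compound 4 (0.07 log units; within the scatter) as its reading, which means the four compounds still form no order and the carbonyl-bound aryl group tolerates all of these changes in this assay. Nothing available gives a cause for any of these steps.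

From the compounds shown here alone, whether an amine, a carboxylic acid or a free hydroxyl on this aromatic carbon would carry the number beyond the scatter stays open. Also open, going by these compounds, is whether a change elsewhere in the shared core, such as a hydroxyl in place of one of its methoxy groups, would do what these aryl substitutions have not.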